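The source may report more compounds than this note shows. Statements on the series, on what has been measured and on what is new or still open speak of the compounds shown alone.

Working notes on the series, read in a functional assay on the whole organism with Rattus norvegicus as the target; a lower number here means that less compound is needed, a higher number that more compound is needed for the effect. Compound 1 `Nc1nc2ccc(I)cc2s1` gives > 10 mg/kg, which is a limit of the assay and not a number. Compound 2 `CCCCCCc1ccc2nc(N)sc2c1` gives 7 mg/kg. Compound 3 `C=CCn1c(=N)sc2cc(OC(F)(F)F)ccc21` gives 7 mg/kg, level with compound 2 within the scatter.

The next compound is compound 4 `N=c1sc2cc(OC(F)(F)F)ccc2n1CCS(N)(=O)=O`, which carries sulfamoylmethyl in place of vinyl on a saturated chain carbon bound to an aromatic nitrogen. Cut one bond further out, the same difference reads allyl to 2-sulfamoylethyl. Among the measured compounds shown here, the series offers no measured step between compounds that differ in one place, so this change has no direct precedent here.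

The starting point is therefore compound 3 at 7 mg/kg, and in this assay only a small shift is expected, leaning towards more compound being needed. The expected size of a 1.1-fold higher number from compound 3 to compound 4 (0.06 log units; within the scatter) stays within the scatter, though with wide uncertainty. For compound 4 the estimate is 8 mg/kg, with an expected range from 3 mg/kg to 20 mg/kg.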

Compound 4, dose for half-maximal effect: 6 mg/kg
Estimate against measurement, compound 4: 1.3-fold (0.12 log units) above; low and high end bracket the measured number.
By their numbers in this assay, from the lowest: compounds 4, 2 and 3 (each within the scatter of the next). At a limit, above all of these: compound 1.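

In this assay, among the compounds shown here, the first step that can be read at this position is a 1.2-fold lower number from compound 3 to compound 4 (0.07 log units; within the scatter). Sulfamoylmethyl in place of vinyl on a saturated chain carbon bound to an aromatic nitrogen therefore adds heavy atoms, a hydrogen-bond donor and hydrogen-bond acceptors, yet the two values stay within the scatter of each other, so this position accepts a larger substituent carrying these features without a readable change in the dose. Nothing measured here bears on why the step is this small.

On these data alone, whether a carboxylic acid, an amine or a longer chain at the same place would also stay level with compound 3 remains open. With a single step at this place, no trend can be drawn for the substituent on this chain.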